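This account rests on a few compounds, and the source may have more. Where it says the series, first, only, none or still open, it means among the compounds named here.

Compound 1 `Cc1nc(S(C)(=O)=O)ccc1Oc1ncnc(OC2CCN(C(=O)OC(C)(C)CF)CC2)c1F`: 19.9 nM
Compound 2 `CCC1(OC(=O)N2CCC(Oc3ncnc(Oc4ccc(S(C)(=O)=O)nc4C)c3F)CC2)CC1`: 22 nM
Compound 3 `Cc1nc(S(C)(=O)=O)ccc1Oc1ncnc(OC2CCN(C(=O)C(F)(F)F)CC2)c1F`: 151 nM

In a functional assay on isolated protein for inhibition of Glucose-dependent insulinotropic receptor (Homo sapiens), read by HTRF and cAMP accumulation (a higher number here means that more compound is needed for the effect, a lower number that less compound is needed), compound 3 gives the highest number of the three measured, with compound 1 at 19.9 nM and compound 2 at 22 nM. Compound 4 `Cc1nc(S(C)(=O)=O)ccc1Oc1ncnc(OC2CCN(C(=O)C3CCCC3)CC2)c1F` differs from compound 3 by cyclopentyl in place of trifluoromethyl on a carbonyl carbon. Among the measured compounds shown here, two measured steps bear on a change on this carbonyl carbon, both read here in the reverse direction: a 7.6-fold higher number from compound 1 to compound 3 (0.88 log units; beyond the scatter) and a 6.9-fold higher number from compound 2 to compound 3 (0.84 log units; beyond the scatter). The pair of carbamates themselves lie close, as a 1.1-fold higher number from compound 1 to compound 2 (0.04 log units; within the scatter) shows. Replacing trifluoromethyl with cyclopentyl is therefore expected to lower the number in this assay, by an estimated 3.8-fold lower number from compound 3 to compound 4 (0.58 log units; beyond the scatter), though a carbon-only ketone is not a direct match for either carbamate, so the expected range is wide. Compound 4 is expected to give 40 nM, between 12 nM and 130 nM.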

Compound 4, half-maximal effective concentration: 72.8 nM
The estimate for compound 4 lay 1.8-fold (0.26 log units) below the measured number; measured number inside the range.
By their numbers in this assay, from the lowest: compounds 1 and 2 (each within the scatter of the next); then compound 4; then compound 3.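

In this assay the step of a 2.1-fold lower number from compound 3 to compound 4 (0.32 log units; beyond the scatter) shows that this carbonyl carbon gives a lower number with cyclopentyl than with trifluoromethyl, even though cyclopentyl carries no fluorine. The cyclopentyl amide still stays short of both carbamates, with a 3.3-fold higher number from compound 2 to compound 4 (0.52 log units; beyond the scatter) and a 3.7-fold higher number from compound 1 to compound 4 (0.56 log units; beyond the scatter) both printed as beyond the scatter. Nothing measured here accounts for these steps.

Open, on these data alone, is whether a cyclopropyl or cyclohexyl ring on the same carbonyl carbon would shift the number further. Also open, as far as these compounds go, is whether cyclopentyl joined through an oxygen, as a carbamate, would match compound 1 and compound 2 in this series.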